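Fused-ring substituent swap in a diaryl urea series

This account rests on a few compounds, and the source may have more. Where it says the series, first, only, none or still open, it means among the compounds named here.

Compound 1 `CCc1ccc2oc(-c3ccc(NC(=O)Nc4cccc(Cl)c4)cc3Cl)cc(=O)c2c1` gives 18% in an ADME assay on QSG7701 cells (Homo sapiens) for inhibition, read by MTT assay, with a stated time of 48 h, tested at 100 uM; a lower number here means a weaker effect, a higher number a stronger effect of the compound at the concentration tested. Compound 2 `CCc1ccc2oc(-c3ccc(NC(=O)Nc4ccc(Cl)cc4)cc3Cl)cc(=O)c2c1` gives 31.8% in this assay, and compound 3 `COc1ccc2oc(-c3ccc(NC(=O)Nc4ccc(Cl)c(Cl)c4)cc3Cl)cc(=O)c2c1` gives 42.5%. Among these three numbers compound 1 stands lowest; the nearest is compound 2 and the furthest is compound 3, and both gaps are beyond the scatter. Among the measured compounds shown here, the only single-place step measured so far, a number 13.8 percentage points higher from compound 1 to compound 2 (beyond the scatter), concerns the chloro position on the urea aryl and is modest. Compound 4 `O=C(Nc1cccc(Cl)c1)Nc1ccc(-c2cc(=O)c3cc(F)ccc3o2)c(Cl)c1` differs from compound 1 by fluoro in place of ethyl on an aromatic carbon of the shared core. For the measured compounds named here, no measured step touches this position on its own. Compound 3 carries methoxy there, but it also carries a different urea aryl, so the gap between compound 1 and compound 3 cannot be split between the two changes, and the step from compound 1 to compound 2 does not bear on the fused-ring position at all. With nothing pointing clearly either way, the expectation for compound 4 is a step of about a number 4 percentage points higher from compound 1 to compound 4 (within the scatter), which lies within the scatter. Compound 4 is therefore estimated at 22%, with a range from 8% to 38%.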

Compound 4, a percentage reported as inhibition, at one concentration (the size of the read-out at that concentration, not a potency): 57.7%
For compound 4 the middle estimate is 35.7 percentage points below the measured one; the measured number lies above the stated range.
By their numbers in this assay, from the lowest: compound 1; then compound 2; then compound 3; then compound 4.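

Among the compounds shown here, on the shared core, the aromatic carbon meta to a fused ring and para to a fused ring proves responsive in this assay: fluoro in place of ethyl gives a number 39.7 percentage points higher from compound 1 to compound 4 (beyond the scatter) and is the first change read at this position on its own. The read-out therefore depends on the substituent at this carbon, even with the urea aryl held as the 3-chlorophenyl group. For the compounds shown here, this large step also sets the position apart from the modest chloro shift on the urea aryl, which gives a number 13.8 percentage points higher from compound 1 to compound 2 (beyond the scatter) and until now was the only single-place change available. Nothing at hand bears on what lies behind the step from ethyl to fluoro.

With only ethyl and fluoro compared directly at this carbon, the compounds shown cannot separate an effect of adding fluoro from one of removing ethyl. Compound 3 carries methoxy at this carbon, but its urea aryl also differs, so methoxy cannot be placed on the same scale. Going by these compounds, it remains open where hydrogen, chloro, an amine or a longer chain at this carbon would fall, and whether the fluoro step would carry over to the 4-chlorophenyl urea of compound 2.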